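The compounds below may be only part of what the source reports. "The series", "measured", "known", "first", "only" and "open" are said of these compounds alone.

Compound 1 `O=C(CSc1nc(Nc2ccccc2)c2ccccc2n1)Nc1ccccc1Br`, compound 2 `O=C(CSc1nc(Nc2ccccc2)c2ccccc2n1)Nc1ccc(Cl)cc1Cl` and compound 3 `C=CC(=O)Nc1cccc(NC(=O)CSc2nc(Nc3ccccc3F)c3ccccc3n2)c1` share a common core and were tested in a functional assay on MDA-MB-231 cells (Homo sapiens) for inhibition, read by MTT assay, with a stated time of 72 h; on this read-out higher numbers stand for weaker inhibition and lower numbers for stronger inhibition. In this assay compound 1 gives 14100 nM, compound 2 gives 19400 nM and compound 3 gives 18700 nM. Compound 3 sits within the scatter of both other compounds, with compound 2 nearest, so the three numbers cannot be told apart. Among the compounds with values here, the only measured step with a single change, a 1.4-fold higher number from compound 1 to compound 2 (0.14 log units; within the scatter), lies within the scatter and concerns the group on the amide-type nitrogen, not the nitrogen on the aromatic ring.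

Compound 4 `C=CC(=O)Nc1cccc(NC(=O)CSc2nc(Nc3ccc(F)cc3)c3ccccc3n2)c1` is the next compound. It differs from compound 3 in that (4-fluorophenyl in place of 2-fluorophenyl on a nitrogen on an aromatic ring). Within the data shown here, no measured step bears directly on this change, as the aryl group on the nitrogen on the aromatic ring is not varied among the three compounds, and the one change elsewhere moved the number within the scatter only. Compound 4 is therefore expected to show a step of a 1.0-fold lower number from compound 3 to compound 4 (0.02 log units; within the scatter), that is, none beyond the scatter. For compound 4 the estimate in this assay is 18000 nM, within a range of 8000 nM to 40000 nM.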

Compound 4, half-maximal inhibitory concentration: 9490 nM
Beside the measured number, compound 4's estimate is 1.9-fold (0.28 log units) above it, and the stated range covers the measured number.
By their numbers in this assay, from the lowest: compounds 4, 1, 3 and 2 (each within the scatter of the next, the first and the last beyond it).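

Within the data shown here, the swap of 2-fluorophenyl for 4-fluorophenyl on a nitrogen on an aromatic ring gives the first reading at this position, and in this assay it comes to a 2.0-fold lower number from compound 3 to compound 4 (0.29 log units; within the scatter). The earlier compounds shown here varied only the group on the amide-type nitrogen, so this shows that moving the fluorine around this phenyl ring also stays inside the scatter, though only just, and compound 3 and compound 4 cannot be told apart. No experimental evidence is available to explain the result.

Going by these compounds, it remains open whether a different group on this nitrogen, such as a pyridyl ring, a cyclohexyl group or a phenyl ring carrying a methoxy group, would move the number beyond the scatter. The compounds shown also leave open how a group other than fluorine on this ring would read.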